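Replacing the cyclopentyl ketone with an ethyl carbamate

A few compounds are considered here, and "the series" means these few. Any claim that something is new, unique, unknown or untested is made for them only; others in the source may bear on it.

The compounds share one core carrying an amino group and a dichlorophenyl ring, and were tested in an assay on Sf9 cells for inhibition of mitogen-activated protein kinase kinase kinase 14 (Homo sapiens), read by ADP-Glo, with a stated time of 60 min; a lower number here means a stronger inhibitor, a higher number a weaker inhibitor. Compound 1 `Cc1[nH]nc(N)c1-c1cc(C(F)(F)F)cc(C(F)(F)F)c1` gives only a limit, > 100000 nM, and no number. Compound 2 `CC(=O)n1nc(C)c(-c2ccc(Cl)c(Cl)c2)c1N` gives 8400 nM. Compound 3 `Cc1nn(C(=O)C2CCCC2)c(N)c1-c1ccc(Cl)c(Cl)c1` gives 41000 nM, the highest of the two numbers measured, with compound 2 its nearest neighbour. Among the measured compounds shown here, the one measured step is a 4.9-fold higher number from compound 2 to compound 3 (0.69 log units; beyond the scatter), so the larger cyclopentyl group on the carbonyl carbon weakened inhibition modestly.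

Compound 4 `CCNC(=O)n1nc(C)c(-c2ccc(Cl)c(Cl)c2)c1N` is not yet measured. It differs from compound 3 by ethylamino in place of cyclopentyl on a carbonyl carbon. The ethylamino group is closer in size to the methyl of compound 2 than to the cyclopentyl of compound 3, so this step is expected to undo part of the loss seen from compound 2 to compound 3. The estimated step is a 3.4-fold lower number from compound 3 to compound 4 (0.53 log units; beyond the scatter). Compound 4 is therefore expected to give about 12000 nM in this assay, within a range from 4000 nM to 40000 nM.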

Compound 4, half-maximal inhibitory concentration: > 100000 nM
Compound 4 gave a limit, no number (the forecaster's own chance of this, stated with the estimate: 5%); at least 8.3-fold (0.92 log units) between middle value and limit.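

Putting ethylamino on the carbonyl carbon gave an at least 2.4-fold higher number from compound 3 to compound 4 (0.38 log units; beyond the scatter), and against the methyl of compound 2 the same group gave an at least 11-fold higher number from compound 2 to compound 4 (1.07 log units; beyond the scatter). So at this position, a group with fewer heavy atoms than cyclopentyl did not bring inhibition back, and heavy-atom count alone does not order these three groups. Compound 4 gives a limit of the assay and not a number, so both steps are minimum sizes, and it shares that ceiling with one other compound: the limit of > 100000 nM in this assay, at which 2 of the 4 values shown sit.

From the compounds shown here alone, what remains open is whether the loss follows the nitrogen and its hydrogen or the ethyl chain. A propyl group on the carbonyl carbon, with carbon in place of that nitrogen, and a dimethylamino group, without the amide hydrogen, would help separate the two.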